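A Fluoro Substitution on Compound 1 Awaits Measurement

The source may hold more compounds than are shown below. What is called first, only, known or untested is meant among the compounds shown, and "the series" means these compounds.

Compound 1 `COC(=O)N1C[C@@H](C)N(c2ncc3[nH]nc(-c4ccc(N5CCN(C)CC5)cc4)c3n2)[C@@H](C)C1` is the reference point of this small set. In an assay on HeLa cells for inhibition of activin receptor type-1 (Homo sapiens), read by HTRF, with stated times of 1 h and 30 min (on this read-out lower numbers stand for stronger inhibition and higher numbers for weaker inhibition), compound 1 gives 61 nM, the lowest of the two numbers obtained. Compound 3 `C[C@@H]1CN(c2ccc(-c3n[nH]c4cnc(N5[C@H](C)CCC[C@@H]5C)nc34)cn2)CCN1` is the nearest of these, and in this assay compound 3 gives 384 nM, a gap that lies beyond the usual scatter. Compound 2 `C[C@@H]1CN(c2ccc(-c3n[nH]c4ccc(N5CCCCC5)nc34)cn2)CCN1` returns only a limit, > 3000 nM in this assay. No two of these compounds differ in a single place, so no measured step between them can be drawn.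

Compound 4 `COC(=O)N1C[C@@H](C)N(c2ncc3[nH]nc(-c4ccc(N5CCN(C)CC5)c(F)c4)c3n2)[C@@H](C)C1` has not yet been measured. It differs from compound 1 by fluoro in place of hydrogen on an aromatic carbon. Among the compounds with values here, no measured step resembles this change. The expectation therefore rests on compound 1 alone. A change of one fluorine is expected to give a step within the scatter, in no definite direction. The estimate for compound 4 in this assay is 55 nM, with a range from 20 nM to 170 nM, meaning an expected step of a 1.1-fold lower number from compound 1 to compound 4 (0.04 log units; within the scatter) that stays within the scatter.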

Compound 4, half-maximal inhibitory concentration: 119 nM
Estimate against measurement, compound 4: 2.2-fold (0.34 log units) below; measured number inside the range.
By their numbers in this assay, from the lowest: compounds 1 and 4 (each within the scatter of the next); then compound 3. At a limit, above all of these: compound 2.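

In this assay, within the data shown here, the step from hydrogen to fluoro on an aromatic carbon gives a 2.0-fold higher number from compound 1 to compound 4 (0.29 log units; within the scatter), and it is the first step in this set that changes a single place. Among these compounds, it shows that this carbon of the six-membered aromatic ring, ortho to the 4-methylpiperazin-1-yl group, can carry a fluoro group with no step beyond the scatter, something the earlier compounds could not show since none of them formed such a pair. Nothing in the data shown bears on why the step has this size.

Going by these compounds, whether a chloro, methyl or methoxy group on this same carbon would also stay within the scatter remains open. So does the outcome of fluoro on another carbon of this ring, or of a morpholine in place of the 4-methylpiperazin-1-yl group beside the fluoro.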